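The source may report more compounds than this note shows. Statements on the series, on what has been measured and on what is new or still open speak of the compounds shown alone.

Measured in an ADME assay on HEK293 cells (Homo sapiens) for cytotoxicity, read by MTT assay, with a stated time of 48 h; a higher number here means a weaker inhibitor, a lower number a stronger inhibitor:

- compound 1 `CCN(CC)CCn1c(N)c(-c2nc3ccccc3[nH]2)c2nc(C#N)c(C#N)nc21`: 12200 nM
- compound 2 `CN(C)CCCn1c(N)c(-c2nc3ccccc3[nH]2)c2nc(C#N)c(C#N)nc21`: 8360 nM
- compound 3 `CCN(CC)CCn1c(N)c(-c2nc3cc(Cl)ccc3[nH]2)c2nc(C#N)c(C#N)nc21`: > 50000 nM, which is a limit of the assay and not a number

Compound 4 `CN(C)CCCn1c(N)c(-c2nc3cc(Cl)ccc3[nH]2)c2nc(C#N)c(C#N)nc21` has not yet been measured in this assay.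

Two changes run through the set. The first is (dimethylamino)methyl in place of diethylamino on a saturated chain carbon, two bonds along the chain from an aromatic nitrogen; in this assay it gives a 1.5-fold lower number from compound 1 to compound 2 (0.16 log units; within the scatter), so compound 1 and compound 2 cannot be ordered against each other here. The second is chloro in place of hydrogen on an aromatic carbon; in this assay it gives an at least 4.0-fold higher number from compound 1 to compound 3 (0.61 log units; beyond the scatter). Its size is known only as a lower bound, because compound 3 sits at the limit of > 50000 nM in this assay, at which 1 of the 3 values shown sits.

Compound 4 stands to compound 3 as compound 2 stands to compound 1: the difference is (dimethylamino)methyl in place of diethylamino on a saturated chain carbon, two bonds along the chain from an aromatic nitrogen, and the place line reads the same word for word in both pairs, so it is the same change. On that basis the step from compound 3 to compound 4 is expected to be small, a number no higher from compound 3 to compound 4 (the limit leaves the size open), resting on a 1.5-fold lower number from compound 1 to compound 2 (0.16 log units; within the scatter) between compound 1 and compound 2. Since compound 3 is known only as a limit, a shift of that size would leave compound 4 near the same limit, with a fair chance that the assay again reports no number. Compound 4 is therefore estimated at 50000 nM, with a range from 25000 nM to 100000 nM.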

Compound 4, half-maximal inhibitory concentration: 11700 nM
The estimate for compound 4 lay 4.3-fold (0.63 log units) above the measured number; measured number outside the range, below it.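

The step of an at least 4.2-fold lower number from compound 3 to compound 4 (0.63 log units; beyond the scatter) does not match the earlier step on the core of compound 1, so in this assay the exchange of diethylamino for (dimethylamino)methyl did not carry over unchanged from one core to the other: the same change on two cores in this assay, a 1.5-fold lower number (0.16 log units; within the scatter) from compound 1 to compound 2 and an at least 4.2-fold lower number (0.63 log units; beyond the scatter) from compound 3 to compound 4, at least 2.9-fold (0.46 log units) apart, beyond the scatter of two such steps

Seen from the other side of the same set of four, the chloro change also differs with the chain, reading a 1.4-fold higher number from compound 2 to compound 4 (0.15 log units; within the scatter) on the (dimethylamino)methyl side, against a larger step on the diethylamino side: the same change on two cores in this assay, an at least 4.0-fold higher number (0.61 log units; beyond the scatter) from compound 1 to compound 3 and a 1.4-fold higher number (0.15 log units; within the scatter) from compound 2 to compound 4, at least 2.9-fold (0.46 log units) apart, beyond the scatter of two such steps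

From the compounds shown here alone, the real size of these gaps stays unknown, as compound 3 gives > 50000 nM, which is a limit of the assay and not a number, and a single pair of cores sets no rule for any further core.

Open, going by these compounds, is which part of the change from 2-(diethylamino)ethyl to 3-(dimethylamino)propyl matters, the chain length or the groups on the amine; a 2-(dimethylamino)ethyl or a 3-(diethylamino)propyl chain on both cores would separate the two. Also open, on these data alone, is whether the same mismatch appears with fluoro or methoxy in place of chloro on that aromatic carbon, or with a cyclic amine such as morpholine at the end of the chain.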